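This account rests on a few compounds, and the source may have more. Where it says the series, first, only, none or still open, it means among the compounds named here.

Working notes on the series. Compound 1 `N/C(=N\NC(=S)N1CCCCCC1)c1ccccn1` and compound 2 `Cc1cccc(/C(N)=N/NC(=S)N2CCCCCC2)n1` share one core; compound 3 `Cc1cccc(/C(N)=N/NC(=S)N2CCCC2)n1` and compound 4 `N/C(=N\NC(=S)N1CCCC1)c1ccccn1` share another. The difference between the two cores is not broken down here.

In a functional assay on HeLa cells (Homo sapiens) for cytotoxicity, read by MTT assay, with a stated time of 72 h, tested at 1 uM (a higher number here means more inhibition of growth at the concentration tested, a lower number less inhibition of growth), compound 2 gives 49.5%. In this assay compound 1 gives 21.3%, and compound 3 gives 8.7%. Compound 3 stands lowest of the three measured numbers, beyond the scatter from compound 1 and further still from compound 2.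

The change from compound 2 to compound 1 is hydrogen in place of methyl on an aromatic carbon. The step it made in this assay was a number 28.2 percentage points lower from compound 2 to compound 1 (beyond the scatter). The change from compound 3 to compound 4 is hydrogen in place of methyl on an aromatic carbon; the place is the same word for word, so this is the same change, now on the second core. Compound 4 has not yet been measured in this assay.

Among the compounds with values here, the earlier step is the only occurrence of this change among the measured compounds, and it was seen on a different core, so its transfer is uncertain. The expected step in this assay is a number 3.7 percentage points lower from compound 3 to compound 4 (within the scatter), smaller than the earlier one, because compound 3 already gives 8.7% and a growth-inhibition read-out has little room left to fall. The estimate for compound 4 in this assay is 5%, with a range from 0% to 20%.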

Compound 4, percent growth inhibition at one concentration: 24.7%
The estimate for compound 4 lay 19.7 percentage points below the measured number; measured number above the stated range.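

In this assay, hydrogen in place of methyl on an aromatic carbon gives a number 16 percentage points higher from compound 3 to compound 4 (beyond the scatter), so the step on the second core runs opposite to the step on the first. The two pairs therefore do not support carrying this change from one core to the other as a fixed increment, in either size or direction: the same change on two cores in this assay, a number 28.2 percentage points lower (beyond the scatter) from compound 2 to compound 1 and a number 16 percentage points higher (beyond the scatter) from compound 3 to compound 4, 44.2 percentage points apart, beyond the scatter of two such steps What this shows is that, within these four compounds, the outcome of removing the methyl depends on the core that carries it; what it does not show is the reason for that dependence, or what the same change would do on any further core, since the comparison rests on just two pairs from a read-out at one concentration.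

The compounds shown leave open whether a different group at the same place on the aromatic ring, such as ethyl, a methoxy group or chlorine, would follow the pattern of the first core or the second. Also open, as far as these compounds go, is whether the opposite steps would persist across a range of concentrations, which a single-concentration growth-inhibition read-out cannot tell.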